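The source may hold more compounds than are shown below. What is called first, only, known or untested is meant among the compounds shown, and "the series" means these compounds.

In a functional assay on HL-60 cells (Homo sapiens) for cytotoxicity, read by MTT assay, with a stated time of 24 h (on this read-out higher numbers stand for weaker inhibition and lower numbers for stronger inhibition), three compounds have been measured so far. Compound 1 `CCCCCCCCCCn1cc(Cn2nc(N)c3c(C(F)(F)F)cc(-c4ccccc4)nc32)nn1` gives 29.9 ug/mL, compound 2 `Nc1nn(Cc2cn(CC(=O)Nc3cccc(F)c3)nn2)c2nc(-c3ccccc3)cc(C(F)(F)F)c12` gives 63.9 ug/mL, and compound 3 `Nc1nn(Cc2cn(CC(=O)Nc3ccccc3Br)nn2)c2nc(-c3ccccc3)cc(C(F)(F)F)c12` gives 27.2 ug/mL, the lowest of the three numbers, although it lies within the scatter of compound 1 and is separated from compound 2 by a 2.3-fold lower number from compound 2 to compound 3 (0.37 log units; beyond the scatter). Compound 4 `Nc1nn(Cc2cn(CC(=O)Nc3ccc(F)cc3Br)nn2)c2nc(-c3ccccc3)cc(C(F)(F)F)c12` differs from compound 3 by a single change: fluoro in place of hydrogen on an aromatic carbon, placed meta to a bromo group and para to a large group. Within the data shown here, no measured step adds a fluoro in this way. The nearest guides are the exchange of the whole aryl group, a 2.3-fold lower number from compound 2 to compound 3 (0.37 log units; beyond the scatter), and the exchange of the chain for the anilide, a 1.1-fold lower number from compound 1 to compound 3 (0.04 log units; within the scatter), both small. The expected step for compound 4 is therefore a 1.1-fold lower number from compound 3 to compound 4 (0.04 log units; within the scatter), none beyond the scatter. The estimate for compound 4 is 25 ug/mL, within a range from 12 ug/mL to 50 ug/mL.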

Compound 4, half-maximal inhibitory concentration: 63.7 ug/mL
For compound 4 the middle estimate is 2.5-fold (0.41 log units) below the measured one; the whole stated range lies below it.
By their numbers in this assay, from the lowest: compounds 3 and 1 (each within the scatter of the next); then compounds 4 and 2 (each within the scatter of the next).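

In this assay, adding one fluoro para to a large group and meta to the bromo group is not a silent change: inhibition weakens (a 2.3-fold higher number from compound 3 to compound 4 (0.37 log units; beyond the scatter)). The anilide can then no longer be told apart from the 3-fluorophenyl one (a 1.0-fold lower number from compound 2 to compound 4 (0.00 log units; within the scatter)), and it now stands clear of the nonyl chain (a 2.1-fold higher number from compound 1 to compound 4 (0.33 log units; beyond the scatter)). Nothing available here explains this shift. Whether the weakening belongs to fluoro itself stays open, since the compounds shown include no chloro or methoxy group on that same carbon.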